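Lactone ring expansion in a discodermolide-type chain

The source may report more compounds than this note shows. Statements on the series, on what has been measured and on what is new or still open speak of the compounds shown alone.

The compounds share a long, branched chain bearing a carbamate and several hydroxyl groups, and differ only in the ring that closes one end. Compound 1 `CC/C=C\[C@H](C)[C@H](OC(N)=O)[C@@H](C)[C@H](O)[C@@H](C)C/C(C)=C\[C@H](C)[C@@H](O)[C@@H](C)/C=C\[C@@H](O)C[C@@H]1OC(=O)[C@H](C)[C@@H](O)[C@H]1C` has "not determined" (no result reported) in a functional assay on A549 cells (Homo sapiens) for antiproliferative activity (on this read-out higher numbers stand for weaker inhibition of growth and lower numbers for stronger inhibition of growth), so no result is reported for it. Compound 2 `CC/C=C\[C@H](C)[C@H](OC(N)=O)[C@@H](C)[C@H](O)[C@@H](C)C/C(C)=C\[C@H](C)[C@@H](O)[C@@H](C)/C=C\[C@@H](O)C[C@@H]1OC(=O)NC[C@H]1C` gives 1000 nM in this assay. Compound 3 `CC/C=C\[C@H](C)[C@H](OC(N)=O)[C@@H](C)[C@H](O)[C@@H](C)C/C(C)=C\[C@H](C)[C@@H](O)[C@@H](C)/C=C\[C@@H](O)C[C@H]1CCC(=O)O1` gives 63 nM, the lowest number of the two and so the stronger growth inhibitor here; the step of a 16-fold lower number from compound 2 to compound 3 (1.20 log units; beyond the scatter) lies beyond the scatter.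

Compound 4 `CC/C=C\[C@H](C)[C@H](OC(N)=O)[C@@H](C)[C@H](O)[C@@H](C)C/C(C)=C\[C@H](C)[C@@H](O)[C@@H](C)/C=C\[C@@H](O)C[C@@H]1OC(=O)[C@H](C)C[C@H]1C` carries the change a group of 9 heavy atoms (7 carbon, 2 oxygen; one six-membered non-aromatic ring with 1 hetero atom) in place of a group of 6 heavy atoms (4 carbon, 2 oxygen; one five-membered non-aromatic ring with 1 hetero atom), on a saturated chain carbon, two bonds along the chain from a double-bonded chain carbon and an oxygen on a saturated carbon at the same position where compound 2 and compound 3 differ. Among the compounds with values here, the only measured step at that place, a 16-fold lower number from compound 2 to compound 3 (1.20 log units; beyond the scatter), was large, which shows this ring is sensitive to change, but it replaced a ring with two hetero atoms by a lactone, whereas here one lactone is exchanged for a larger lactone. Both compound 3 and compound 4 therefore keep a lactone, and a smaller step is expected. For compound 4 a value of 40 nM is estimated, within 10 nM to 160 nM, meaning an expected step of a 1.6-fold lower number from compound 3 to compound 4 (0.20 log units; within the scatter) that may well fall within the scatter.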

Compound 4, concentration for 50% growth inhibition: 50 nM
For compound 4 the middle estimate is 1.3-fold (0.10 log units) below the measured one, within the range that was stated.
By their numbers in this assay, from the lowest: compounds 4 and 3 (each within the scatter of the next); then compound 2.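

Within this assay, the larger ring is tolerated at this position on a saturated chain carbon: exchanging the group with one five-membered non-aromatic ring for the group with one six-membered non-aromatic ring gives a 1.3-fold lower number from compound 3 to compound 4 (0.10 log units; within the scatter), so these two compounds cannot be told apart in this assay. The large drop seen earlier therefore no longer rests on one ring alone, since compound 4 also shows a 20-fold lower number from compound 2 to compound 4 (1.30 log units; beyond the scatter), and among the three compounds with numbers, the ring holding a nitrogen, that of compound 2, is the one that stands apart. No supporting measurement is available to explain this difference between the rings.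

These few compounds cannot separate the effect of ring size from that of the methyl groups on the six-membered ring, and a ring of the same size without those methyl groups would be needed to do so. On these data alone, it also remains open whether the ring has to be closed at all, as a chain ending in a carboxylic acid, or a seven-membered lactone, could give a quite different number.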